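Swapping the Bromophenyl for a Methyl(phenyl)amino Group

The source may report more compounds than this note shows. Statements on the series, on what has been measured and on what is new or still open speak of the compounds shown alone.

Measured so far:
compound 1 `CC(O)(C(=O)Nc1ccc(S(=O)(=O)c2ccc(F)cc2)cc1)C(F)(F)F` gives 8600 nM in a functional assay (Cavia porcellus) with sulfonylurea receptors; K-ATP channels (Homo sapiens) as the target; on this read-out lower numbers stand for stronger inhibition and higher numbers for weaker inhibition;
compound 2 `Cc1cccc(S(=O)(=O)c2ccc(NC(=O)C(C)(O)C(F)(F)F)cc2)c1` gives 2200 nM;
compound 3 `CC(O)(C(=O)Nc1ccc(S(=O)(=O)c2ccc(Br)cc2)cc1)C(F)(F)F` gives > 30000 nM.

The value of compound 3 is a limit of the assay rather than a number (the limit of > 30000 nM in this assay, at which 1 of the 3 values shown sits). Both steps reaching compound 3 went toward weaker inhibition: an at least 3.4-fold higher number from compound 1 to compound 3 (0.54 log units; beyond the scatter) and an at least 13-fold higher number from compound 2 to compound 3 (1.13 log units; beyond the scatter). Compound 4 `CN(c1ccccc1)S(=O)(=O)c1ccc(NC(=O)C(C)(O)C(F)(F)F)cc1` carries methyl(phenyl)amino in place of 4-bromophenyl on a sulfonyl sulfur. The nearest measured step is the one on the same sulfonyl sulfur, an at least 13-fold higher number from compound 2 to compound 3 (1.13 log units; beyond the scatter), which shows that leaving the 4-bromophenyl can be worth a large step toward stronger inhibition. Going by the values given here, no measured compound carries a nitrogen on that sulfur, so the direction is uncertain. Compound 4 is therefore expected to show an at least 3.0-fold lower number from compound 3 to compound 4 (0.47 log units; beyond the scatter), with an estimated value of 10000 nM and a range from 2000 nM to 50000 nM.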

Compound 4, half-maximal inhibitory concentration: 2000 nM
The estimate for compound 4 lay 5.0-fold (0.70 log units) above the measured number, and the stated range covers the measured number.
By their numbers in this assay, from the lowest: compounds 4 and 2 (each within the scatter of the next); then compound 1. At a limit, above all of these: compound 3.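

Compound 4 shows that the sulfonyl sulfur can carry a nitrogen instead of a directly attached aromatic ring and keep the level of the best aryl group seen so far: a 1.1-fold lower number from compound 2 to compound 4 (0.04 log units; within the scatter). Against 4-fluorophenyl, the same change gives a 4.3-fold lower number from compound 1 to compound 4 (0.63 log units; beyond the scatter), and against 4-bromophenyl it gives an at least 15-fold lower number from compound 3 to compound 4 (1.17 log units; beyond the scatter). Compound 3 stands at a limit, so that last step is only a bound: the limit of > 30000 nM in this assay, at which 1 of the 4 values shown sits.

Still open, on these data alone, is whether the methyl on the nitrogen or its phenyl matters more. A piperidine or morpholine on the same sulfur could test this.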